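Swapping the sulfur-linked side chain of compound 2 for a cyclohexylsulfonyl

The source may report more compounds than this note shows. Statements on the series, on what has been measured and on what is new or still open speak of the compounds shown alone.

Of the compounds shown here, two have been measured so far. Among the measured compounds shown here, compound 1 `CC(C(=O)NCc1ccc(C(F)(F)F)nc1SCCOc1ccccc1)c1ccc(NS(C)(=O)=O)c(F)c1` gives 2.3 nM in an assay on CHO-K1 cells for antagonist activity at transient receptor potential cation channel subfamily V member 1 (Homo sapiens), read by FLIPR (on this read-out lower numbers stand for stronger inhibition and higher numbers for weaker inhibition), and compound 2 `COC(=O)CCSc1nc(C(F)(F)F)ccc1CNC(=O)C(C)c1ccc(NS(C)(=O)=O)c(F)c1` gives 48.2 nM, the highest of the two numbers; the only step measured, a 21-fold higher number from compound 1 to compound 2 (1.32 log units; beyond the scatter), shows that what sits on this aromatic carbon of the shared core matters strongly. Compound 3 `CC(C(=O)NCc1ccc(C(F)(F)F)nc1S(=O)(=O)C1CCCCC1)c1ccc(NS(C)(=O)=O)c(F)c1` has not been measured. It differs from compound 2 by cyclohexylsulfonyl in place of (2-(methoxycarbonyl)ethyl)sulfanyl on an aromatic carbon. For the measured compounds named here, the one measured step bears on this change only loosely, since here a ring replaces an open chain and a sulfonyl replaces a sulfanyl, so no measured pair mirrors it directly. Because a 21-fold higher number from compound 1 to compound 2 (1.32 log units; beyond the scatter) was large and the ester variant gave the weaker number, a lower number for compound 3 is expected, with wide uncertainty, a step of a 4.0-fold lower number from compound 2 to compound 3 (0.60 log units; beyond the scatter). Compound 3 is therefore estimated at 12 nM, within a range from 2.5 nM to 60 nM.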

Compound 3, inhibition constant: "not active" (no number reported)
Compound 3: no number reported; the estimate stays without a comparison.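

Among the compounds shown here, compound 3 is reported as not active in this assay without a number, and no step from compound 2 to compound 3 can be read. Nothing measured here accounts for this result. The compounds shown leave open whether the sulfonyl link or the cyclohexyl ring decides that outcome.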